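This account rests on a few compounds, and the source may have more. Where it says the series, first, only, none or still open, it means among the compounds named here.

Of the compounds shown here, two that share a common core have been measured so far. Compound 1 `Cc1cc(C)c(S(=O)(=O)N2CCC(N3CCC(C)CC3)CC2)c(C)c1` carries methyl groups on its aromatic ring, and in a functional assay on DLD-1 cells (Homo sapiens) for antiproliferative activity, read by CellTiter-Glo, with a stated time of 72 h (a lower number here means a stronger inhibitor, a higher number a weaker inhibitor), compound 1 gives 0.03 nM. Compound 2 `CC1CCN(C2CCN(S(=O)(=O)c3ccc(-c4ccccc4F)cc3)CC2)CC1` carries a 2-fluorophenyl group on that ring instead, and in this assay compound 2 gives 5 nM. Of the two numbers measured, the value of compound 2 is the higher one, so it is the weaker inhibitor; compound 1 stands far lower, and the gap between them lies well beyond the usual scatter.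

Compound 3 `CCCCOc1ccc(S(=O)(=O)N2CCC(N3CCC(C)CC3)CC2)cc1` has not yet been measured. Compared with compound 2, its change is butoxy in place of 2-fluorophenyl on an aromatic carbon. For the measured compounds named here, no measured pair differs in exactly this way, so the size of the step is uncertain. Compound 1, with a small substituent on that ring, gives 0.03 nM, which points toward a lower number for compound 3. In this assay the expected step is a 5.0-fold lower number from compound 2 to compound 3 (0.70 log units; beyond the scatter). For compound 3 the estimate in this assay is 1 nM, with a range from 0.1 nM to 10 nM.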

Compound 3, half-maximal inhibitory concentration: 2300 nM
Estimate against measurement, compound 3: 2300-fold (3.36 log units) below, outside the stated range (above it).
By their numbers in this assay, from the lowest: compound 1; then compound 2; then compound 3.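

In this assay, putting butoxy in place of 2-fluorophenyl on this aromatic carbon, para to a large group, gives a 460-fold higher number from compound 2 to compound 3 (2.66 log units; beyond the scatter), a large step towards a weaker inhibitor, so this position is far from indifferent to the group it carries. The change does several things at once: an aromatic ring leaves, an open chain enters, and a hydrogen-bond acceptor is added, so this single step cannot show which of these differences counts. No measurement shown here speaks to what lies behind the step.

As far as these compounds go, it remains open whether the weaker result follows the loss of the ring or the arrival of the oxygen atom, a question that a plain butyl chain or an unsubstituted phenyl ring at the same carbon could help to separate. From the compounds shown here alone, it is also open how a shorter methoxy group, or a group of a different kind such as an amine or a carboxylic acid, would fare at this place on the shared core.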